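Propyl at the aromatic nitrogen of the shared core

The compounds below may be only part of what the source reports. "The series", "measured", "known", "first", "only" and "open" are said of these compounds alone.

Working notes on a series sharing the core of compound 1 `CCCCn1cnc2c(NCc3ccc(C(=O)Nc4ccccc4N)cc3)nc(Cl)nc21`. In a functional assay on HepG2 cells (Homo sapiens) for antiproliferative activity, read by CCK-8 assay, with a stated time of 72 h, tested at 8 uM (on this read-out higher numbers stand for a stronger effect at the one concentration tested and lower numbers for a weaker effect), compound 1 gives 19.6%. Compound 2 `CC(C)n1cnc2c(NCc3ccc(C(=O)Nc4ccccc4N)cc3)nc(Cl)nc21` gives 74.4%, and compound 3 `Nc1ccccc1NC(=O)c1ccc(CNc2nc(Cl)nc3c2ncn3C2CCCC2)cc1` gives 74.9%. Compound 3 holds the highest of the three numbers, but its gap to compound 2 is within the scatter (a number 0.5 percentage points higher from compound 2 to compound 3 (within the scatter)), so the two cannot be ordered; only compound 1 sits clearly apart (a number 55.3 percentage points higher from compound 1 to compound 3 (beyond the scatter) and a number 54.8 percentage points higher from compound 1 to compound 2 (beyond the scatter)).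

Compound 4 `CCCn1cnc2c(NCc3ccc(C(=O)Nc4ccccc4N)cc3)nc(Cl)nc21` is not yet measured. It differs from compound 3 as follows: propyl in place of cyclopentyl on an aromatic nitrogen. For the measured compounds named here, two measured steps bear on this change. The step from isopropyl to cyclopentyl left the read-out unchanged (a number 0.5 percentage points higher from compound 2 to compound 3 (within the scatter)), whereas the step from butyl to cyclopentyl was large (a number 55.3 percentage points higher from compound 1 to compound 3 (beyond the scatter)). Propyl, like butyl, has no ring, yet it is a shorter chain and nearer in heavy-atom count to isopropyl, so the available steps point in opposite directions and the size of the move is uncertain.

On balance a moderate downward step is expected, a number 29.9 percentage points lower from compound 3 to compound 4 (beyond the scatter), with wide bounds. Compound 4 is therefore estimated at 45% in this assay, within a range from 15% to 75%.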

Compound 4, a percentage reported as inhibition, at one concentration (the size of the read-out at that concentration, not a potency): 14.1%
Beside the measured number, compound 4's estimate is 30.9 percentage points above it, outside the stated range (below it).
By their numbers in this assay, from the lowest: compounds 4 and 1 (each within the scatter of the next); then compounds 2 and 3 (each within the scatter of the next).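

In this assay this position on the aromatic nitrogen proves sharply sensitive to the shape of the group, not only to its size: propyl in place of isopropyl gives a number 60.3 percentage points lower from compound 2 to compound 4 (beyond the scatter). Propyl in place of cyclopentyl is also a large step, a number 60.8 percentage points lower from compound 3 to compound 4 (beyond the scatter), whereas shortening butyl to propyl leaves the read-out unchanged, a number 5.5 percentage points lower from compound 1 to compound 4 (within the scatter). The four compounds therefore form two groups, with propyl and butyl low and isopropyl and cyclopentyl high, none of the four goes against this split or lies between the groups, and no measurement at hand accounts for the split.

Still open, from the compounds shown here alone, is whether branched butyl groups such as isobutyl or tert-butyl, a small ring such as cyclopropyl, or a longer chain such as hexyl would fall with compound 2 and compound 3 or with compound 1 and compound 4. Each read-out also comes from a single concentration, so the compounds shown do not tell whether compound 2 and compound 3 share a potency as well as a percentage.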